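This account rests on a few compounds, and the source may have more. Where it says the series, first, only, none or still open, it means among the compounds named here.

In a functional assay on PC-3 cells (Homo sapiens) for cytotoxicity, read by XTT assay, with a stated time of 72 h (a lower number here means a stronger inhibitor, a higher number a weaker inhibitor), compound 1 `COc1ccc(OC)c(-c2cc(-c3ccc(C(=O)N4CCCCC4)s3)on2)c1` gives only a limit, > 30000 nM. For the measured compounds named here, compound 2 `CCN(CC)C(=O)c1ccc(-c2cc(C3=CC(=O)C=CC3=O)no2)s1` gives 8900 nM in this assay, and this is the only actual number among the two values shown, the other sitting at the limit of > 30000 nM in this assay, at which 1 of the 2 values shown sits. Compound 3 `O=C1C=CC(=O)C(c2cc(-c3ccc(C(=O)NCC4CC4)s3)on2)=C1` has not yet been tested in this assay. (cyclopropylmethyl)amino in place of diethylamino on a carbonyl carbon Since the quinone and the rest of the shared core are kept, the expected step is modest, a 1.0-fold higher number from compound 2 to compound 3 (0.00 log units; within the scatter), with no direction beyond the scatter. Compound 3 is therefore estimated at 9000 nM in this assay, within a range from 3000 nM to 30000 nM.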

Compound 3, half-maximal inhibitory concentration: > 30000 nM
Compound 3: only a limit was reported (the forecaster's own chance of this, stated with the estimate: 15%); at least 3.3-fold (0.52 log units) between middle value and limit.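

In this assay, the group on this carbonyl carbon matters even with the quinone kept: (cyclopropylmethyl)amino in place of diethylamino gives an at least 3.3-fold higher number from compound 2 to compound 3 (0.52 log units; beyond the scatter). The full size of this step cannot be read, as compound 3 gives only a limit. Compound 2 thus remains the only compound here with an actual number: the limit of > 30000 nM in this assay, at which 2 of the 3 values shown sit.

The change brings in the amide hydrogen and the three-membered ring together, and the compounds shown do not separate the two. Going by these compounds, an ethylamino group would carry the hydrogen without the ring, while a pyrrolidine would carry a ring without the hydrogen; how either behaves here remains open.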